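Adding a Bromo Group to Compound 2

This account rests on a few compounds, and the source may have more. Where it says the series, first, only, none or still open, it means among the compounds named here.

- Compound 1 `O=C(Nc1ccc(C(F)(F)F)cc1)c1cc(Br)c(-c2ccccc2)cc1O` gives 400 nM
- Compound 2 `N#Cc1ccc(NC(=O)c2ccc(-c3ccccc3)cc2O)cc1` gives 410 nM
- Compound 3 `N#Cc1ccc(NC(=O)c2ccc(F)cc2O)cc1` gives 3150 nM

These three numbers come from a functional assay on KG-1 cells (Homo sapiens) for cytotoxicity, read by luminescence and CellTiter-Glo, with a stated time of 3 days (a higher number here means a weaker inhibitor, a lower number a stronger inhibitor), where a small number marks a compound that stops the cells at a low concentration. Compound 2 lies within the scatter of compound 1 , and these two sit at the low end of the three numbers, well apart from compound 3 .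

The next compound to be tested is compound 4 `N#Cc1ccc(NC(=O)c2cc(Br)c(-c3ccccc3)cc2O)cc1`. It differs from compound 2 by one change: bromo in place of hydrogen on an aromatic carbon. A bromo group thus takes the place of a hydrogen on the aromatic carbon ortho to a phenyl group.

Among the measured compounds shown here, the only measured step is a 7.7-fold higher number from compound 2 to compound 3 (0.89 log units; beyond the scatter). It replaces the phenyl group with fluoro and adds no bromo, so it shows that this assay responds to change in these compounds but gives no direct size for this one. For the measured compounds named here, no measured step isolates the bromo group. Going by the values given here, the closest hint is compound 1 , the only measured compound with a bromo group, which gives 400 nM, close to the number of compound 2 .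

No shift beyond the scatter is therefore expected, and the estimated change is a 1.1-fold lower number from compound 2 to compound 4 (0.03 log units; within the scatter). For compound 4 the expected value is 380 nM, with an estimated range of 150 nM to 950 nM.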

Compound 4, half-maximal inhibitory concentration: 850 nM
The estimate for compound 4 lay 2.2-fold (0.35 log units) below the measured number; the range from low to high includes it.
By their numbers in this assay, from the lowest: compounds 1 and 2 (each within the scatter of the next); then compound 4; then compound 3.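

In this assay, among the compounds shown here, the aromatic carbon ortho to a phenyl group and para to a hydroxy group does not tolerate every change without effect: bromo in place of hydrogen gives a 2.1-fold higher number from compound 2 to compound 4 (0.32 log units; beyond the scatter), a modest loss of strength that no earlier pair of compounds could isolate. With the bromo group held in place, the group at the far end of the molecule also counts, as cyano in place of trifluoromethyl gives a 2.1-fold higher number from compound 1 to compound 4 (0.33 log units; beyond the scatter). Compound 1 was thus a poor guide to the bromo group alone, as it differs from compound 2 in two places, so its close number says little about either change on its own. Nothing available explains why either change raises the number.

The compounds shown leave open whether this step belongs to bromine in particular or would appear with any group on this carbon, and a chloro, methyl or amino group there would help to separate the two. They also leave open whether the bromo step would keep its size with trifluoromethyl in place of cyano.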